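A few compounds are considered here, and "the series" means these few. Any claim that something is new, unique, unknown or untested is made for them only; others in the source may bear on it.

Measured so far, in a functional assay on the whole organism for inhibition, with Rattus norvegicus as the target; on this read-out lower numbers stand for an effect already at smaller amounts and higher numbers for an effect only at larger amounts of compound:

- compound 1 `CC1CC/C(=N\Nc2ccccc2Cl)c2ncc(C(=O)O)c(=O)n21` gives > 1000 umol/kg, which is a limit of this assay.
- compound 2 `CC1CC/C(=N\Nc2cccc(Br)c2)c2ncc(C(=O)O)c(=O)n21` gives > 320 umol/kg, also a limit.
- compound 3 `Cc1ccc(N/N=C2\CCC(C)n3c2ncc(C(=O)O)c3=O)cc1` gives > 1000 umol/kg, again a limit.

Compound 3 therefore stands at a limit, not at a number, and it shares that limit with compound 1 (the limit of > 1000 umol/kg in this assay, at which 2 of the 3 values shown sit), while compound 2 sits at a different limit (the limit of > 320 umol/kg in this assay, at which 1 of the 3 values shown sits). The steps a step that the two limits leave unreadable from compound 1 to compound 2, a step that the two limits leave unreadable from compound 1 to compound 3 and a step that the two limits leave unreadable from compound 2 to compound 3 are all left unreadable by these limits, so none of them tells how large a change in the group on the amine nitrogen matters here.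

Compound 4 `CNC(=O)c1ccc(N/N=C2\CCC(C)n3c2ncc(C(=O)O)c3=O)cc1` differs from compound 3 in one place: methylcarbamoyl in place of methyl on an aromatic carbon. For the measured compounds named here, no measured step bears on this change with a readable size, so no direction can be drawn from the three compounds; the only pattern visible is that every compound stays at a limit. Compound 4 is expected to behave likewise, with an estimated step of a number no higher from compound 3 to compound 4 (the limit leaves the size open) in this assay. The estimate for compound 4 is 1000 umol/kg, within a range from 300 umol/kg to 3000 umol/kg.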

Compound 4, dose for 50% inhibition: > 100 umol/kg
Compound 4 was reported as a limit; the forecaster's own chance of this, stated with the estimate: 75%; the middle value does not contradict the limit.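

For compound 4 the value of > 100 umol/kg is a limit, not a number. Compound 3 at > 1000 umol/kg is also a limit, so the step between these two compounds cannot be read. Still open, as far as these compounds go, is whether methylcarbamoyl in place of methyl changes the effect in this assay at all.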